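The source may hold more compounds than are shown below. What is called first, only, known or untested is meant among the compounds shown, and "the series" means these compounds.

Measured in a functional assay on HCT-116 cells (Homo sapiens) for cytotoxicity, read by MTT assay, with a stated time of 72 h; on this read-out higher numbers stand for weaker inhibition and lower numbers for stronger inhibition:
Compound 1 `C[C@@H](Nc1c(C(=O)NCc2ccc(F)cc2)nc(Br)c2cccnc12)c1ccccc1`: > 20000 nM, a limit
Compound 2 `N[C@H]1CC[C@H](Nc2c(C(=O)NCc3ccc(F)cc3)nc(Br)c3cccnc23)CC1`: 4000 nM
Compound 3 `O=C(NCCCNc1c(C(=O)NCc2ccc(F)cc2)nc(Br)c2cccnc12)c1ccccc1`: > 10000 nM, a limit

Compound 3 reads > 10000 nM, which is a limit and not an exact number. Compound 1 reads > 20000 nM, which is also a limit. Among these three, only compound 2 has an exact number, 4000 nM.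

The next compound to consider is compound 4 `NCCNc1c(C(=O)NCc2ccc(F)cc2)nc(Br)c2cccnc12`. It differs from compound 3 as follows: amino in place of benzamidomethyl on a saturated chain carbon, two bonds along the chain from a nitrogen on an aromatic ring.

Among the compounds with values here, only one measured step bears on this change, and only loosely: an at least 5.0-fold lower number from compound 1 to compound 2 (0.69 log units; beyond the scatter). In that step, 1-phenylethyl leaves and 4-aminocyclohexyl enters, so there too a group with an aromatic ring of carbon only gives way to one holding an amino group. The two changes are not the same, and the groups differ in size and shape, so this single step is a rough guide. It points to a lower number of similar size in this assay. The expected step is an at least 2.0-fold lower number from compound 3 to compound 4 (0.30 log units; that floor lies within the scatter). For compound 4, the estimated value is 5000 nM, with an expected range from 1500 nM to 15000 nM.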

Compound 4, half-maximal inhibitory concentration: > 20000 nM
Compound 4 ended at the assay's limit; the forecaster's own chance of this, stated with the estimate: 25%; at least 4.0-fold (0.60 log units) between middle value and limit.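

In this assay compound 4 gives > 20000 nM, which is a limit and not an exact number. Putting 2-aminoethyl in place of 4-aminocyclohexyl gives an at least 5.0-fold higher number from compound 2 to compound 4 (0.69 log units; beyond the scatter), so among the compounds shown, an amino group on this nitrogen substituent does not by itself bring the lower number, and what carries the amino group matters. The steps to compound 4 from compound 1 and from compound 3 cannot be read, because each of them joins two limits: the limit of > 20000 nM in this assay, at which 2 of the 4 values shown sit.

From the compounds shown here alone, it remains open whether the ring of the 4-aminocyclohexyl group or simply the greater distance of its amino group from the shared core goes with the value of compound 2, 4000 nM. A longer straight chain ending in an amine, such as 4-aminobutyl, would help separate these two readings, while a piperidin-4-yl ring or a chain ending in a carboxylic acid would test how much the ring and the amine themselves contribute.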